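This account rests on a few compounds, and the source may have more. Where it says the series, first, only, none or still open, it means among the compounds named here.

Measured compounds:

Compound 1 `Cn1ncc2c(-c3ccccc3)cc(NNC(=O)Nc3cc(Cl)nc(Cl)c3)nc21`: 1020 nM
Compound 2 `CCCOc1cc(NC(=O)NNc2cc(-c3ccc(OC)cc3)c3cnn(C)c3n2)cc(Cl)n1`: 3140 nM
Compound 3 `COc1cc(NC(=O)NNc2cc(-c3ccc(F)cc3)c3cnn(C)c3n2)cc(OC)c1OC`: 4440 nM

These three compounds share a core and were tested in an assay on isolated protein for binding affinity to sphingosine 1-phosphate receptor 2 (Homo sapiens), read by surface plasmon resonance; a higher number here means weaker binding, a lower number tighter binding. Compound 2 gives 3140 nM, which places it second highest among the three numbers. Its nearest neighbour is compound 3 at 4440 nM; the gap between them is within the scatter of repeated measurements, so no order can be read between the two. Compound 1, at 1020 nM, sits lower by a margin that lies beyond the scatter, so it binds more tightly than compound 2.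

Compound 4 `CCCCOc1cc(NC(=O)NNc2cc(-c3ccc(OC)cc3)c3cnn(C)c3n2)cc(Cl)n1` has not yet been measured. It differs from compound 2 by methyl in place of hydrogen on a saturated chain carbon, three bonds along the chain from an oxygen on an aromatic ring, that is, propyl to butyl at the chain attached to the aromatic oxygen. Going by the values given here, no measured pair differs in this way, so nothing in the data shows what such a lengthening does here. Among the compounds with values here, with only this change, the step from compound 2 to compound 4 is expected to be a 1.1-fold lower number from compound 2 to compound 4 (0.03 log units; within the scatter), no larger than the scatter in either direction. Compound 4 is therefore estimated at 2900 nM, with a range from 1300 nM to 6500 nM.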

Compound 4, dissociation constant: 4150 nM
Beside the measured number, compound 4's estimate is 1.4-fold (0.16 log units) below it, within the range that was stated.
By their numbers in this assay, from the lowest: compound 1; then compounds 2, 4 and 3 (each within the scatter of the next).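

Swapping propyl for butyl at the chain attached to the aromatic oxygen gives, in this assay, a 1.3-fold higher number from compound 2 to compound 4 (0.12 log units; within the scatter) and so leaves the two compounds indistinguishable. Going by these compounds alone, this is the first measured pair that differs in one place only, and it shows that, at this end of the chain, methyl in place of hydrogen makes no readable difference to binding. No other measurement bears on this result.

On these data alone, it remains open whether a longer chain such as hexyl, a branched one such as isopropyl, or a chain ending in an amine or a carboxylic acid would move the number beyond the scatter. As far as these compounds go, it is also open whether propyl to butyl would read the same with a group other than methoxy on the aromatic ring of the shared core.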